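Swaps at one aromatic oxygen: cytotoxicity notes

The compounds below may be only part of what the source reports. "The series", "measured", "known", "first", "only" and "open" are said of these compounds alone.

Measured so far:
compound 1 `COc1ccc(/C=C/C(=O)c2ccc(OC)c3c2OC(C)(C)C=C3)cc1OCCCN(C)C`: 8600 nM
compound 3 `COc1ccc(/C=C/C(=O)c2ccc(OC)c3c2OC(C)(C)C=C3)cc1OC(=O)c1ccc(Br)cc1`: 8400 nM
compound 2 `CCC(=O)Oc1cc(/C=C/C(=O)c2ccc(OC)c3c2OC(C)(C)C=C3)ccc1OC`: > 10000 nM, a limit of the assay

In an ADME assay on L02 cells (Homo sapiens) for cytotoxicity, read by MTT assay (on this read-out higher numbers stand for weaker inhibition and lower numbers for stronger inhibition), compound 1 holds the highest of the two numbers; compound 3 sits nearest, with a 1.0-fold lower number from compound 1 to compound 3 (0.01 log units; within the scatter). Compound 2 gives only a limit, (the limit of > 10000 nM in this assay, at which 1 of the 3 values shown sits). The unmeasured compound 4 `COc1ccc(/C=C/C(=O)c2ccc(OC)c3c2OC(C)(C)C=C3)cc1OS(=O)(=O)Cc1ccccc1` differs from compound 1 by benzylsulfonyl in place of 3-(dimethylamino)propyl on an oxygen on an aromatic ring. Two measured steps from compound 1 change the same oxygen: an at least 1.1-fold higher number from compound 1 to compound 2 (0.06 log units; that floor lies within the scatter) and a 1.0-fold lower number from compound 1 to compound 3 (0.01 log units; within the scatter); neither leaves the scatter, and the step of an at least 1.1-fold lower number from compound 2 to compound 3 (0.07 log units; that floor lies within the scatter) does not either. Compound 4 is therefore expected to show no step beyond the scatter in this assay, with a 1.0-fold higher number from compound 1 to compound 4 (0.01 log units; within the scatter). The estimate for compound 4 is 8800 nM, between 5000 nM and 16000 nM.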

Compound 4, half-maximal inhibitory concentration: > 10000 nM
Compound 4 was reported as a limit (the forecaster's own chance of this, stated with the estimate: 30%); middle value at least 1.1-fold (0.05 log units) away from the limit.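

In this assay, for the compounds shown here, benzylsulfonyl on this oxygen adds a third kind of group, linked through sulfur, and still no step leaves the scatter: an at least 1.1-fold higher number from compound 1 to compound 4 (0.06 log units; that floor lies within the scatter), and an at least 1.1-fold higher number from compound 3 to compound 4 (0.07 log units; that floor lies within the scatter). Both are floors only, and the step between compound 2 and compound 4 cannot be read, since both values are limits. More of the series now rests on a limit: the limit of > 10000 nM in this assay, at which 2 of the 4 values shown sit.

Going by these compounds, how far compound 2 and compound 4 lie past that limit stays open, so any true gap to compound 1 has no size yet. Also open, on these data alone, is whether a free hydroxyl, a carboxylic acid or a longer amine chain on this oxygen would give a step beyond the scatter.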